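Para-substituent swap on the benzyl ring of compound 1

The source may hold more compounds than are shown below. What is called first, only, known or untested is meant among the compounds shown, and "the series" means these compounds.

Compound 1 `CCOC(=O)c1ccc(CO/N=C/c2c(C)nn(C)c2Oc2ccc(Cl)cc2)cc1` stands highest of the three measured compounds in a functional assay on MKN-45 cells (Homo sapiens) for antiproliferative activity, tested at 1 uM (on this read-out lower numbers stand for less inhibition and higher numbers for more inhibition at the one concentration tested (going by the name of the read-out)), where compound 1 gives 20.9%. Compound 2 `CCOC(=O)c1ccc(CO/N=C/c2c(C)nn(-c3ccccc3)c2Oc2ccc(Cl)cc2)cc1` gives -17.8% and compound 3 `Cc1nn(C)c(Oc2ccccc2)c1/C=N/OCc1cccc(-c2ccccc2)c1C` gives -12.1% in this assay. Within the data shown here, the only single-point step measured, a number 38.7 percentage points lower from compound 1 to compound 2 (beyond the scatter), concerns the substituent on the aromatic nitrogen and does not touch the benzyl ring. Compound 4 `Cc1ccc(CO/N=C/c2c(C)nn(C)c2Oc2ccc(Cl)cc2)cc1` differs from compound 1 by methyl in place of ethoxycarbonyl on an aromatic carbon. No measured pair isolates this change, so the direction of the step is open; on the shown numbers no step beyond the scatter is expected, with a wide range around that expectation. The step from compound 1 is estimated as a number 8.9 percentage points lower from compound 1 to compound 4 (within the scatter). For compound 4 the expected value is 12%, within -15% to 35%.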

Compound 4, a percentage reported as inhibition, at one concentration (the size of the read-out at that concentration, not a potency): 30.4%
Compound 4: middle estimate off by 18.4 percentage points, on the low side, within the range that was stated.
By their numbers in this assay, from the lowest: compounds 2 and 3 (each within the scatter of the next); then compounds 1 and 4 (each within the scatter of the next).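

In this assay, among these compounds, the one step at this place, para to a large group, is a number 9.5 percentage points higher from compound 1 to compound 4 (within the scatter). Methyl therefore holds the read-out of the shared core as well as ethoxycarbonyl does, so the larger group with its hydrogen-bond acceptors is not needed at this concentration. Nothing available bears on why the two groups read alike.

Going by these compounds, whether a carboxylic acid or an amine at this place would hold the same level stays open. Also open, on these data alone, is whether methyl there would behave alike with phenyl on the aromatic nitrogen, as in compound 2.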